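The compounds below may be only part of what the source reports. "The series", "measured", "known", "first", "only" and "open" are said of these compounds alone.

Of the compounds shown here, three have been measured in an assay on isolated protein for inhibition of cathepsin S (Homo sapiens); a lower number here means a stronger inhibitor, a higher number a weaker inhibitor. Compound 1 `CC(=O)N1CCc2c(c(-c3ccc(OC(F)(F)F)cc3)nn2CC(O)CN2CCC(n3c(O)nc4ccccc43)CC2)C1` gives 130 nM. For the measured compounds named here, compound 2 `CC(=O)N1CCc2c(c(-c3ccc(Br)cc3)nn2CC(O)CN2CCC(n3c(O)nc4ccccc43)CC2)C1` gives 80 nM; the only change, bromo in place of trifluoromethoxy on an aromatic carbon, brought a 1.6-fold lower number from compound 1 to compound 2 (0.21 log units; within the scatter). Compound 3 `CCn1c(=O)n(C2CCN(CC(O)Cn3nc(-c4ccc(Cl)c(C)c4)c4c3CCN(C(C)=O)C4)CC2)c2ccccc21` gives 310 nM, the highest of the three numbers, beyond the scatter from both compound 1 and compound 2.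

Compound 4 `CC(=O)N1CCc2c(c(-c3ccc(Cl)c(C)c3)nn2CC(O)CN2CCC(n3c(=O)n(C(C)C)c4ccccc43)CC2)C1` keeps everything of compound 3 except (methyl in place of hydrogen on a saturated chain carbon bound to an aromatic nitrogen and a saturated chain carbon); the same difference, cut one bond further out, reads ethyl to isopropyl. Going by the values given here, none of the measured steps touches this position: the only measured step, from compound 1 to compound 2, changes a group on an aromatic ring elsewhere in the molecule, so it says nothing about a methyl added here. Among the compounds with values here, with no comparable step to lean on, the expected outcome is a change within the scatter, that is, a 1.0-fold lower number from compound 3 to compound 4 (0.01 log units; within the scatter) in this assay. Compound 4 is therefore estimated at 300 nM, with a range from 110 nM to 800 nM.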

Compound 4, half-maximal inhibitory concentration: 100 nM
For compound 4 the middle estimate is 3.0-fold (0.48 log units) above the measured one; the whole stated range lies above it.
By their numbers in this assay, from the lowest: compounds 2, 4 and 1 (each within the scatter of the next); then compound 3.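

In this assay, adding a single methyl on a saturated chain carbon bound to an aromatic nitrogen and a saturated chain carbon, which turns ethyl into isopropyl, gives a 3.1-fold lower number from compound 3 to compound 4 (0.49 log units; beyond the scatter), a step beyond the usual scatter. This shows that the position responds to a small change, which the earlier step could not show, since that step changed a group on an aromatic carbon elsewhere and stayed within the scatter. Nothing available here explains why this extra methyl goes with a lower number.

As far as these compounds go, it remains open whether growing the group further, to tert-butyl or a longer chain such as n-butyl, or closing it into a cyclopropyl ring, would lower the number again or raise it. From the compounds shown here alone, it is equally open whether an amine or a carboxylic acid at the end of such a chain would be tolerated here.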